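The compounds below may be only part of what the source reports. "The series", "measured", "known", "first", "only" and "open" are said of these compounds alone.

Measured in a functional assay on HT-29 cells (Homo sapiens) for antiproliferative activity, read by sulforhodamine B assay, with a stated time of 72 h; a lower number here means a stronger inhibitor, a higher number a weaker inhibitor:
- compound 1 `S=C(N/N=C/c1ccc2ccccc2n1)Nc1cccc(Br)c1`: 58900 nM
- compound 2 `Cc1ccccc1NC(=S)N/N=C/c1ccc2ccccc2n1`: 42300 nM
- compound 3 `S=C(N/N=C/c1ccc2ccccc2n1)Nc1ccccc1Br`: > 100000 nM

For compound 3 the result > 100000 nM is a limit of the assay and not a number.

Compound 4 `COc1ccc(NC(=S)N/N=C/c2ccc3ccccc3n2)cc1` has 4-methoxyphenyl in place of 2-bromophenyl on an amide-type nitrogen.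

Three measured steps change the group at this same place. With 2-methylphenyl in place of 3-bromophenyl, the result is a 1.4-fold lower number from compound 1 to compound 2 (0.14 log units; within the scatter). With 2-bromophenyl in place of 3-bromophenyl, the result is an at least 1.6-fold higher number from compound 1 to compound 3 (0.22 log units; that floor lies within the scatter). With bromo in place of methyl on an aromatic carbon, the result is an at least 2.3-fold higher number from compound 2 to compound 3 (0.37 log units; beyond the scatter). None of these steps tests 4-methoxyphenyl, so the expectation rests on what leaves rather than on what enters.

Compound 1 at 58900 nM and compound 2 at 42300 nM both lack 2-bromophenyl, so a modest step to a lower number is expected in this assay once that group is gone. The expected change is an at least 2.5-fold lower number from compound 3 to compound 4 (0.39 log units; beyond the scatter). Compound 4 is estimated at 40000 nM, with an expected range from 12000 nM to 100000 nM.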

Compound 4, half-maximal inhibitory concentration: 82300 nM
Beside the measured number, compound 4's estimate is 2.1-fold (0.31 log units) below it; low and high end bracket the measured number.
By their numbers in this assay, from the lowest: compounds 2, 1 and 4 (each within the scatter of the next). At a limit, above all of these: compound 3.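

In this assay, 4-methoxyphenyl is the only group shown on the amide-type nitrogen that carries oxygen, and it gives a 1.9-fold higher number from compound 2 to compound 4 (0.29 log units; within the scatter) and a 1.4-fold higher number from compound 1 to compound 4 (0.15 log units; within the scatter), so swapping in this hydrogen-bond acceptor leaves compound 4 within the scatter of both compounds and sets no order among them. The remaining comparison is an at least 1.2-fold lower number from compound 3 to compound 4 (0.08 log units; that floor lies within the scatter), and with a floor of that size it does not establish a real difference, whereas compound 3 did stand apart from compound 2 beyond the scatter. The result for compound 3 is a limit of the assay and not a number: the limit of > 100000 nM in this assay, at which 1 of the 4 values shown sits.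

The compounds shown therefore leave open how far compound 3 really lies from the other three, and whether any change at this place on the shared core can move the number beyond the scatter in either direction. An amine or a carboxylic acid on the phenyl ring, or a longer alkyl chain in place of that ring, could test this, as all four groups shown are substituted phenyl rings.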